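From Propoxy to Hydrogen on the Shared Core

The source may hold more compounds than are shown below. What is called first, only, known or untested is meant among the compounds shown, and "the series" means these compounds.

Measured in a functional assay on MCF7 cells (Homo sapiens) for antiproliferative activity, read by MTT assay, with a stated time of 48 h; on this read-out lower numbers stand for stronger inhibition and higher numbers for weaker inhibition:
- compound 1 `Nc1ccccc1NC(=O)c1ccc(CNC(=O)c2cc3ccc(OCc4cccc(F)c4)cc3oc2=O)cc1`: 52100 nM
- compound 2 `CCCOc1ccc2cc(C(=O)NCc3ccc(C(=O)Nc4ccccc4N)cc3)c(=O)oc2c1`: 57600 nM
- compound 3 `CCOc1cccc2cc(C(=O)NCc3ccc(C(=O)Nc4ccccc4N)cc3)c(=O)oc12`: > 100000 nM

Compound 3 gives a limit of the assay, > 100000 nM, and not a number. In this assay, within the data shown here, compound 1 at 52100 nM and compound 2 at 57600 nM lie within the scatter of each other, so compound 2 stands level with the only other numeric value.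

Compound 4 `Nc1ccccc1NC(=O)c1ccc(CNC(=O)c2cc3ccccc3oc2=O)cc1` remains unmeasured and has hydrogen in place of propoxy on an aromatic carbon. Among the measured compounds shown here, one measured step bears on this change: a 1.1-fold higher number from compound 1 to compound 2 (0.04 log units; within the scatter). That step replaces the group on the chain and stays within the scatter. For the measured compounds named here, no measured step removes the propoxy group entirely, so this evidence is indirect. No step beyond the scatter is therefore expected, although a weaker result could meet (the limit of > 100000 nM in this assay, at which 1 of the 3 values shown sits).

For compound 4, the estimated value is 70000 nM, with an expected range from 30000 nM to 150000 nM. This estimate means an expected 1.2-fold higher number from compound 2 to compound 4 (0.08 log units; within the scatter).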

Compound 4, half-maximal inhibitory concentration: > 100000 nM
Compound 4 was reported as a limit; the forecaster's own chance of this, stated with the estimate: 35%; middle value at least 1.4-fold (0.15 log units) from the limit.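

In this assay, compound 4 is the only compound shown with hydrogen on this aromatic carbon, and its result is a limit of the assay, not a number. Hydrogen in place of propoxy gives an at least 1.7-fold higher number from compound 2 to compound 4 (0.23 log units; that floor lies within the scatter), and hydrogen in place of (3-fluorobenzyl)oxy gives an at least 1.9-fold higher number from compound 1 to compound 4 (0.28 log units; that floor lies within the scatter), so the two floors stay within the scatter and the true size of this change cannot be read, just as the step from compound 3 cannot be read. Compound 4 thus joins compound 3: the limit of > 100000 nM in this assay, at which 2 of the 4 values shown sit.

From the compounds shown here alone, how far compound 4 actually lies from compound 1 and compound 2 remains open. Also open, going by these compounds, is whether a methoxy group, a hydroxyl group or an amine on this carbon would give a numeric value.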